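Thiazole substituent swap on a weak pyrimidinylamine inhibitor

A few compounds are considered here, and "the series" means these few. Any claim that something is new, unique, unknown or untested is made for them only; others in the source may bear on it.

Measured compounds:
compound 1 `COc1ccc(Nc2nccc(-c3cn(C4CCCC4)c4ccccc34)n2)c(OC)c1`: 1740 nM
compound 2 `CCSc1nc(C)c(-c2ccnc(Nc3ccc(OC)cc3OC)n2)s1`: 32400 nM

In a functional assay on MV4-11 cells (Homo sapiens) for inhibition, read by resazurin assay, with a stated time of 72 h (on this read-out lower numbers stand for stronger inhibition of growth and higher numbers for weaker inhibition of growth), compound 2 gives the highest of the two numbers, and the nearest compound, compound 1, sits far below it, a gap well beyond the scatter. Compound 3 `COCCOc1nc(C)c(-c2ccnc(Nc3ccc(OC)cc3OC)n2)s1` differs from compound 2 in one place: 2-methoxyethoxy in place of ethylsulfanyl on an aromatic carbon. Within the data shown here, no measured pair follows such an exchange, so there is nothing to anchor the direction of the step; the chain entering and the chain leaving both lack donors, and the rest of the structure is unchanged. The expectation is that the step of a 1.1-fold lower number from compound 2 to compound 3 (0.03 log units; within the scatter) stays within the scatter, with no clear direction. On that basis compound 3 is estimated at 30000 nM in this assay, between 8000 nM and 100000 nM.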

Compound 3, concentration for 50% growth inhibition: 1980 nM
For compound 3 the middle estimate is 15-fold (1.18 log units) above the measured one; measured number below the stated range.
By their numbers in this assay, from the lowest: compounds 1 and 3 (each within the scatter of the next); then compound 2.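

In this assay, 2-methoxyethoxy in place of ethylsulfanyl gives a 16-fold lower number from compound 2 to compound 3 (1.21 log units; beyond the scatter), so growth inhibition responds strongly to the chain on this aromatic carbon, next to the ring nitrogen and next to the ring sulfur. The exchange replaces a chain of 3 heavy atoms with 1 hydrogen-bond acceptor by one of 5 heavy atoms with 2 hydrogen-bond acceptors, and it removes the chain's sulfur while the rest of the structure stays unchanged. Nothing available explains the step or ties it to any one of these differences.

From the compounds shown here alone, whether the step follows the ether oxygens or the chain length stays open; a plain propyl ether, a longer ether chain or an amine on the same carbon would separate these readings. Also open, going by these compounds, is whether the methyl group on the same ring has any part in the step.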